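Swapping benzyl for tert-butyl on a nitrone nitrogen

The source may report more compounds than this note shows. Statements on the series, on what has been measured and on what is new or still open speak of the compounds shown alone.

Of the compounds shown here, three that share one core have been tested in a functional assay on COLO 205 cells (Homo sapiens) for inhibition, read by MTT assay, with a stated time of 24 h (on this read-out lower numbers stand for stronger inhibition and higher numbers for weaker inhibition), and each reached only the limit of that assay. Compound 1 `[O-]/[N+](=C\c1cn(-c2ccccc2)nn1)c1ccccc1` gives > 100000 nM, a limit rather than a number. Compound 2 `[O-]/[N+](=C\c1cn(-c2ccccc2)nn1)Cc1ccccc1` likewise gives > 100000 nM, again a limit. Compound 3 `COc1ccc(-n2cc(/C=[N+](\[O-])Cc3ccccc3)nn2)cc1` gives > 100000 nM, also a limit. Within the data shown here, because of this, the change from compound 1 to compound 2 is a step that the two limits leave unreadable from compound 1 to compound 2, and the change from compound 2 to compound 3 is a step that the two limits leave unreadable from compound 2 to compound 3; the only evidence is the limit of > 100000 nM in this assay, at which 3 of the 3 values shown sit.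

Compound 4 `CC(C)(C)/[N+]([O-])=C/c1cn(-c2ccccc2)nn1` differs from compound 2 in one place: tert-butyl in place of benzyl on a double-bonded nitrogen. Among the measured compounds shown here, no measured step reads on this change, since every value so far sits at the limit, so no shift in either direction can be predicted from the data. The expectation for compound 4 is therefore that it stays near the limit, with an estimated value of 150000 nM in this assay, within a range from 30000 nM to 600000 nM, which corresponds to an expected step that the limit leaves unreadable from compound 2 to compound 4.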

Compound 4, half-maximal inhibitory concentration: 15200 nM
For compound 4 the middle estimate is 9.9-fold (0.99 log units) above the measured one; measured number below the stated range.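

Among these compounds, compound 4 is the only one of the four compounds with a number rather than a limit, so the group on the double-bonded nitrogen can clearly change the result in this assay. Tert-butyl in place of benzyl gives an at least 6.5-fold lower number from compound 2 to compound 4 (0.81 log units; beyond the scatter), and tert-butyl in place of phenyl gives an at least 6.5-fold lower number from compound 1 to compound 4 (0.81 log units; beyond the scatter). The earlier steps cannot be read, and these two new steps give only minimum sizes, since the other compounds stop at a limit: the limit of > 100000 nM in this assay, at which 3 of the 4 values shown sit.

As far as these compounds go, it remains open whether a different group on this nitrogen, such as isopropyl or cyclohexyl, would give a lower or a higher number than tert-butyl. From the compounds shown here alone, it also remains open whether methoxy in place of hydrogen on an aromatic carbon, the change seen in compound 3, would shift the number of compound 4.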